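Fluoro to isopropoxy: how far might the number move?

A few compounds are considered here, and "the series" means these few. Any claim that something is new, unique, unknown or untested is made for them only; others in the source may bear on it.

In an ADME assay on HT-29 cells (Homo sapiens) for cytotoxicity, read by MTT assay, with a stated time of 72 h (a higher number here means a weaker inhibitor, a lower number a stronger inhibitor), compound 3 `COc1ccc(C2=C(c3cc(OC)c(OC)c(OC)c3)C(=O)C(O)C2)cc1F` gives < 1 ug/mL as a limit of the assay, not a number. Compound 2 `COc1ccc(C2=C(c3cc(OC)c(OC)c(OC)c3)C(=O)C(O)C2)cc1Cl` gives < 1 ug/mL, also a limit. Compound 1 `COc1ccc(C2=C(c3cc(OC)c(OC)c(OC)c3)C(=O)C(O)C2)cc1NC(=O)c1ccccc1` gives > 100 ug/mL, a limit at the opposite end. Compounds 2 and 3 thus share (the limit of < 1 ug/mL in this assay, at which 2 of the 3 values shown sit), while compound 1 stands at the limit of > 100 ug/mL in this assay, at which 1 of the 3 values shown sits.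

Compound 4 `COc1ccc(C2=C(c3cc(OC)c(OC)c(OC)c3)C(=O)C(O)C2)cc1OC(C)C` has not yet been measured. It carries isopropoxy in place of fluoro on an aromatic carbon, ortho to a methoxy group: isopropoxy in place of fluoro on an aromatic carbon.

Within the data shown here, three measured steps bear on this change, all at the same place. Chloro in place of benzamido gives an at least 100-fold lower number from compound 1 to compound 2 (2.00 log units; beyond the scatter), and fluoro in place of benzamido gives an at least 100-fold lower number from compound 1 to compound 3 (2.00 log units; beyond the scatter). Both are large. Fluoro in place of chloro gives a step that the two limits leave unreadable from compound 2 to compound 3, so it shows no size at all. Among the measured compounds shown here, neither chloro nor fluoro is isopropoxy, and benzamido is the only group here that comes with a high number, so the data bracket compound 4 only loosely. A moderate move towards a higher number, a weaker result, is expected in this assay, far short of the steps from benzamido. The expected change is an at least 3.0-fold higher number from compound 3 to compound 4 (0.47 log units; beyond the scatter), and it rests on a limit. For compound 4 the estimate is 3 ug/mL, with an expected range from 0.5 ug/mL to 30 ug/mL.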

Compound 4, half-maximal inhibitory concentration: > 100 ug/mL
Compound 4: only a limit was reported (the forecaster's own chance of this, stated with the estimate: 35%); middle value at least 33-fold (1.52 log units) away from the limit.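

In this assay, isopropoxy in place of fluoro gives an at least 100-fold higher number from compound 3 to compound 4 (2.00 log units; beyond the scatter), and isopropoxy in place of chloro gives an at least 100-fold higher number from compound 2 to compound 4 (2.00 log units; beyond the scatter), so a high number at this place no longer belongs to benzamido alone. Isopropoxy, with 4 heavy atoms and no ring, is enough on this aromatic carbon, ortho to a methoxy group, to turn a compound at the low limit into one at the high limit. Compound 4 gives > 100 ug/mL, which is a limit of the assay, and no value shown now lies between the two ends: the limit of > 100 ug/mL in this assay, at which 2 of the 4 values shown sit.

From the compounds shown here alone, every value shown is a limit, so the steps between compound 1 and compound 4 and between compound 2 and compound 3 cannot be read, and how far any compound lies past its limit stays unknown. The compounds shown leave open whether a hydroxyl, an amine or an ethoxy group at this place would sit at either limit or between them, and so where along the way from fluoro to isopropoxy the number turns.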